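The compounds below may be only part of what the source reports. "The series", "measured", "known", "first", "only" and "open" are said of these compounds alone.

Compound 1 `CON(C)C(=O)c1ccc(-c2csc3c(OC4CCN(C(=O)OC(C)(C)C)CC4)ncnc23)cc1` and compound 2 `CON(C)C(=O)c1ccc(-c2csc3c(OC4CCN(C(=O)OC(C)(C)C)CC4)ncnc23)cc1F` share one core, and compound 3 `CCc1cnc(N2CCC(COc3ccc(-c4ccc(C(=O)N(C)OC)cc4)nc3)CC2)nc1` is built on a different core; the difference between the two cores is not broken down here. In a functional assay on cells for agonist activity at Glucose-dependent insulinotropic receptor (Homo sapiens), read by a luciferase reporter, with a stated time of 6 h (a higher number here means that more compound is needed for the effect, a lower number that less compound is needed), compound 1 gives 64 nM, and compound 2 gives 57 nM, so that a 1.1-fold lower number from compound 1 to compound 2 (0.05 log units; within the scatter), a change made by fluoro in place of hydrogen on an aromatic carbon. On its own core compound 3 gives 319 nM, the highest of the three numbers, beyond the scatter from both compound 1 and compound 2.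

Compound 4 `CCc1cnc(N2CCC(COc3ccc(-c4ccc(C(=O)N(C)OC)c(F)c4)nc3)CC2)nc1` has not yet been measured. It differs from compound 3 by fluoro in place of hydrogen on an aromatic carbon, the same kind of change that separates compound 1 from compound 2, at a place described in the same words. For the measured compounds named here, because the one measured example of this change, a 1.1-fold lower number from compound 1 to compound 2 (0.05 log units; within the scatter), stayed within the scatter, the step from compound 3 to compound 4 is expected to be small as well, about a 1.1-fold lower number from compound 3 to compound 4 (0.04 log units; within the scatter). Compound 4 is therefore estimated to give 290 nM, with a likely range from 150 nM to 600 nM.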

Compound 4, half-maximal effective concentration: 77 nM
The estimate for compound 4 lay 3.8-fold (0.58 log units) above the measured number, and the stated range ends above it.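

In this assay, fluoro in place of hydrogen on an aromatic carbon gave a 4.1-fold lower number from compound 3 to compound 4 (0.62 log units; beyond the scatter), on a six-membered aromatic ring of carbon only and ortho to a methoxy(methyl)carbamoyl group. Set beside the earlier example, the step differs, so in this series the size of this change did not carry over from one core to the other: the same change on two cores in this assay, a 1.1-fold lower number (0.05 log units; within the scatter) from compound 1 to compound 2 and a 4.1-fold lower number (0.62 log units; beyond the scatter) from compound 3 to compound 4, 3.7-fold (0.57 log units) apart, beyond the scatter of two such steps The comparison rests on a single pair of compounds on each core, so it does not show which difference between the cores goes with the larger step, nor what the same change would do on a third core.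

The compounds shown leave open whether chloro or methyl at this place would behave as fluoro does on either core. They also leave open whether the difference between the two steps would persist with a carboxylic acid or a primary amide in place of the methoxy(methyl)carbamoyl group.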